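Swapping a pentyl chain for nitro on an amide-linked phenoxyacetamide

The source may report more compounds than this note shows. Statements on the series, on what has been measured and on what is new or still open speak of the compounds shown alone.

Of the compounds shown here, three that share a phenoxyacetamide core have been measured in an assay for inhibition of malate dehydrogenase, cytoplasmic (Homo sapiens), with a stated time of 30 min; a lower number here means a stronger inhibitor, a higher number a weaker inhibitor. Compound 1 `CCCCCc1ccc(OCC(=O)Nc2cccc(C(=O)OC)c2)cc1` gives 6790 nM in this assay, the highest of the three numbers and therefore the weakest inhibitor of the set. Compound 3 `COC(=O)c1cccc(NC(=O)C(C)(C)Oc2ccc(C(C)(C)CC(C)(C)C)cc2)c1` gives 1400 nM, a lower number than compound 1 by a margin beyond the scatter. Compound 2 `C#CCOC(=O)c1ccc(O)c(NC(=O)COc2ccc(C(C)(C)CC(C)(C)C)cc2)c1` gives 920 nM, the lowest number of the three and again beyond the scatter relative to compound 1.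

Compound 4 `COC(=O)c1cccc(NC(=O)COc2ccc([N+](=O)[O-])cc2)c1` has not yet been measured. It differs from compound 1 in one place: nitro in place of pentyl on an aromatic carbon. Within the data shown here, both compound 2 and compound 3 carry a bulky branched alkyl chain on that ring; no measured compound has a small polar group there, so the expectation rests on thin ground. The step from compound 1 to compound 4 is expected to raise the number by more than the scatter, as a 2.9-fold higher number from compound 1 to compound 4 (0.47 log units; beyond the scatter). In this assay compound 4 is expected to give about 20000 nM, somewhere between 6000 nM and 80000 nM.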

Compound 4, half-maximal inhibitory concentration: > 40000 nM
Compound 4: a limit, no number; the forecaster's own chance of this, stated with the estimate: 30%; middle value at least 2.0-fold (0.30 log units) away from the limit.
By their numbers in this assay, from the lowest: compounds 2 and 3 (each within the scatter of the next); then compound 1. At a limit, above all of these: compound 4.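

In this assay compound 4 gives > 40000 nM, a limit of the assay and not a number. The earlier compounds shown here all carry an alkyl chain on this aromatic carbon, para to a large group, so they could not show what happens without one; nitro in place of pentyl gives an at least 5.8-fold higher number from compound 1 to compound 4 (0.77 log units; beyond the scatter), so inhibition is sensitive to the group at this position. From the compounds shown here alone, only a lower bound on that step can be read, and its true size stays unknown: the limit of > 40000 nM in this assay, at which 1 of the 4 values shown sits.

The compounds shown leave open whether the higher number follows the loss of the pentyl chain or the arrival of the nitro, as both happen in one step. A methyl group, a methoxy group or an amine at this position could help separate the two, and a longer chain would test the other direction.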